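This account rests on a few compounds, and the source may have more. Where it says the series, first, only, none or still open, it means among the compounds named here.

In a functional assay on SGC-7901 cells (Homo sapiens) for inhibition, read by MTT assay, with a stated time of 24 h (on this read-out lower numbers stand for stronger inhibition and higher numbers for weaker inhibition), compound 1 `CC1(C)[C@H]2CC[C@]1(C)N(Cc1cn(-c3ccc(C#N)cc3)nn1)C(=O)C2`, which carries a cyano group on its phenyl ring, gives 500 nM. Compound 2 `CC1(C)[C@H]2CC[C@]1(C)N(Cc1cn(-c3ccc(O)cc3)nn1)C(=O)C2`, with a hydroxy group in that place, gives 330 nM, and compound 3 `CC1(C)[C@H]2CC[C@]1(C)N(Cc1cn(-c3ccccc3)nn1)C(=O)C2`, with an unsubstituted phenyl, gives 240 nM.

Hydrogen in place of cyano gives a 2.1-fold lower number from compound 1 to compound 3 (0.32 log units; beyond the scatter), a modest change. Hydrogen in place of hydroxy gives a 1.4-fold lower number from compound 2 to compound 3 (0.14 log units; within the scatter), and hydroxy in place of cyano gives a 1.5-fold lower number from compound 1 to compound 2 (0.18 log units; within the scatter). Compound 3 thus stands clear of compound 1, but it cannot be told apart from compound 2.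

Compound 4 `Cc1ccccc1-n1cc(CN2C(=O)C[C@@H]3CC[C@@]2(C)C3(C)C)nn1` differs from compound 3 in one place: methyl in place of hydrogen on an aromatic carbon. This is methyl in place of hydrogen on an aromatic carbon, ortho to a large group, which turns phenyl into 2-methylphenyl.

Among the measured compounds shown here, none of the measured steps involves a methyl group, so they bear on this change only indirectly. They show what swapping one group on the same phenyl ring has done so far, and the largest of them is the modest step from cyano to hydrogen. No direction can be read from them for a methyl group, so no change beyond the scatter is expected in this assay.

The expected step is a 1.1-fold higher number from compound 3 to compound 4 (0.05 log units; within the scatter). The estimated value for compound 4 is 270 nM, with a range of 110 nM to 600 nM.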

Compound 4, half-maximal inhibitory concentration: 350 nM
Compound 4: middle estimate off by 1.3-fold (0.11 log units), on the low side; the range from low to high includes it.
By their numbers in this assay, from the lowest: compounds 3, 2, 4 and 1 (each within the scatter of the next, the first and the last beyond it).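

In this assay, placing a methyl group on the phenyl ring, ortho to a large group, gives a 1.5-fold higher number from compound 3 to compound 4 (0.16 log units; within the scatter), so the 2-methylphenyl of compound 4 cannot be told apart from the unsubstituted phenyl of compound 3. Among the compounds shown here, the cyano and hydroxy groups of the earlier compounds sit elsewhere on the ring, as their names 4-cyanophenyl and 4-hydroxyphenyl show, and neither comparison with the new ring separates the compounds: 2-methylphenyl in place of 4-hydroxyphenyl gives a 1.1-fold higher number from compound 2 to compound 4 (0.03 log units; within the scatter), and 2-methylphenyl in place of 4-cyanophenyl gives a 1.4-fold lower number from compound 1 to compound 4 (0.15 log units; within the scatter). Compound 4 therefore sits within the scatter of all three earlier compounds, and nothing available explains these results.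

From the compounds shown here alone, whether a methoxy group, a chlorine atom or an amine at this same ring carbon would also stay within the scatter of compound 3 remains open. So does how a methyl group would read on other ring carbons, as in 4-methylphenyl, which would allow a direct comparison with the cyano and hydroxy groups of compound 1 and compound 2.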